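The source may report more compounds than this note shows. Statements on the series, on what has been measured and on what is new or still open speak of the compounds shown alone.

Measured so far:
compound 1, `COc1ccc(C)cc1NC(=S)N/N=C/c1ccc2ccccc2n1` — > 100000 nM
compound 2, `CC(C)c1cccc(C(C)C)c1NC(=S)N/N=C/c1ccc2ccccc2n1` — 19500 nM
compound 3, `CN(C)C(=S)N/N=C/c1ccc2ccccc2n1` — 50 nM

All three share one core and differ only at the thiourea end. In a functional assay on HL-60 cells (Homo sapiens) for antiproliferative activity, read by sulforhodamine B assay, with a stated time of 72 h (on this read-out higher numbers stand for weaker inhibition and lower numbers for stronger inhibition), compound 3 gives 50 nM. Compound 2 gives 19500 nM in this assay. Compound 1 is recorded in this assay only as a limit, > 100000 nM; it sits at the limit of > 100000 nM in this assay, at which 1 of the 3 values shown sits, so no number is known for it, only that it falls at the limit.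

Compound 4, `COc1ccccc1NC(=S)N/N=C/c1ccc2ccccc2n1`, is still to be measured in this assay. Compared with compound 1 it shows (hydrogen in place of methyl on an aromatic carbon). Going by the values given here, no measured pair in the set tells how a change of this kind moves the read-out, so the size of the step is open. The expectation is that the step from compound 1 to compound 4 stays small, an at least 1.2-fold lower number from compound 1 to compound 4 (0.09 log units; that floor lies within the scatter), with no clear shift beyond the scatter in either direction. For compound 4 the estimate in this assay is 80000 nM. Compound 4 is expected to fall between 15000 nM and 400000 nM, with a real chance that only a limit is reported.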

Compound 4, half-maximal inhibitory concentration: 91700 nM
Estimate against measurement, compound 4: 1.1-fold (0.06 log units) below; measured number inside the range.
By their numbers in this assay, from the lowest: compound 3; then compound 2; then compound 4. At a limit, above all of these: compound 1.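

In this assay compound 1 is a limit and not a number (> 100000 nM). Hydrogen in place of methyl, on the aromatic carbon para to a methoxy group, gives an at least 1.0-fold lower number from compound 1 to compound 4 (0.03 log units; that floor lies within the scatter) and so no step beyond the scatter can be claimed for this change. The methyl at this position is thus not shown to matter for the read-out, and compound 4 gives this part of the series a measured reference in place of a limit.

As far as these compounds go, whether another group on this carbon, such as an amine, a carboxylic acid or a longer chain, would move the read-out beyond the scatter stays open. The true size of this step also stays unread because compound 1 is held at a limit: the limit of > 100000 nM in this assay, at which 1 of the 4 values shown sits.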